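The source may report more compounds than this note shows. Statements on the series, on what has been measured and on what is new or still open speak of the compounds shown alone.

These three compounds have been measured in a functional assay on HT-29 cells (Homo sapiens) for antiproliferative activity, read by MTT assay, with a stated time of 48 h; on this read-out lower numbers stand for stronger inhibition of growth and higher numbers for weaker inhibition of growth:

compound 1, `S=C(Nc1ccccc1)N1N=C(c2ccccc2)CC1c1ccc2c(c1)OCCO2`, gives 6630 nM
compound 2, `S=C(Nc1ccccc1)N1N=C(c2ccc(Cl)cc2)CC1c1ccc2c(c1)OCCO2`, gives 187000 nM
compound 3, `O=[N+]([O-])c1ccc(C2=NN(C(=S)Nc3ccccc3)C(c3ccc4c(c3)OCCO4)C2)cc1`, gives 153000 nM

All three share one core and differ only in the group on the carbon that carries a double bond to nitrogen in the five-membered ring. Compound 3 stands second highest of the three numbers. Its nearest neighbour is compound 2, and the two cannot be told apart in this assay: a 1.2-fold lower number from compound 2 to compound 3 (0.09 log units; within the scatter). Compound 1 lies far off: a 23-fold higher number from compound 1 to compound 3 (1.36 log units; beyond the scatter).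

Compound 4, `S=C(Nc1ccccc1)N1N=C(c2ccc(Cl)c(Cl)c2)CC1c1ccc2c(c1)OCCO2`, has not yet been measured. Its change from compound 3 is 3,4-dichlorophenyl in place of 4-nitrophenyl on a carbon with a double bond to nitrogen.

Going by the values given here, two measured steps bear on this. Putting chloro in place of hydrogen on the aromatic carbon gave a large weakening: a 28-fold higher number from compound 1 to compound 2 (1.45 log units; beyond the scatter). Exchanging that chloro for nitro made no difference beyond the scatter: a 1.2-fold lower number from compound 2 to compound 3 (0.09 log units; within the scatter). Among the compounds with values here, compound 4 keeps a chloro at the same place as compound 2 and adds a second one; no measured pair shows what that second chloro does. The expectation is therefore a number close to compound 2 and compound 3, with a step of a 1.1-fold higher number from compound 3 to compound 4 (0.05 log units; within the scatter) that is not expected to exceed the scatter.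

For compound 4 in this assay the estimate is 170000 nM, expected to fall between 40000 nM and 600000 nM.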

Compound 4, concentration for 50% growth inhibition: 95300 nM
For compound 4 the middle estimate is 1.8-fold (0.25 log units) above the measured one, and the stated range covers the measured number.
By their numbers in this assay, from the lowest: compound 1; then compounds 4, 3 and 2 (each within the scatter of the next).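

In this assay, the 3,4-dichlorophenyl group cannot be told apart from 4-nitrophenyl at this position (a 1.6-fold lower number from compound 3 to compound 4 (0.21 log units; within the scatter)), and the added chloro that separates compound 4 from compound 2 also stays inside the scatter (a 2.0-fold lower number from compound 2 to compound 4 (0.29 log units; within the scatter)). The gap to the plain phenyl group is still wide (a 14-fold higher number from compound 1 to compound 4 (1.16 log units; beyond the scatter)), so the weaker growth inhibition seen with the single chloro and the nitro group also holds for a ring carrying two chloro groups, and compound 1 alone stands apart among these four. Nothing measured here explains why any of these groups gives a higher number than plain phenyl.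

The compounds shown carry only chloro and nitro on this ring, so it remains open whether a methyl, a methoxy, an amine or a carboxylic acid in the same place would also raise the number as far or would stay close to compound 1. As far as these compounds go, it is also open whether a single chloro or nitro at another ring carbon would behave like the groups in compound 2 and compound 3.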